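A few compounds are considered here, and "the series" means these few. Any claim that something is new, unique, unknown or untested is made for them only; others in the source may bear on it.

Three compounds have so far been measured in an ADME assay (liver) for metabolic stability, with Liver microsome (Rattus norvegicus) as the target, using microsomes and NADPH, with a stated time of 30 min, tested at 1 uM; on this read-out higher numbers stand for fast clearance and lower numbers for slow clearance:

Compound 1, `Nc1ccc(S(=O)(=O)N2CCN(c3ncc(C(O)(C(F)(F)F)C(F)(F)F)cc3C#CCO)CC2)cn1`: 65 mL.min-1.g-1
Compound 2, `Cn1cc(-c2cc(C(O)(C(F)(F)F)C(F)(F)F)cnc2N2CCN(S(=O)(=O)c3ccc(N)nc3)CC2)cn1`: 44 mL.min-1.g-1
Compound 3, `CCn1cc(-c2cc(C(O)(C(F)(F)F)C(F)(F)F)cnc2N2CCN(S(=O)(=O)c3ccc(N)nc3)CC2)cn1`: 194 mL.min-1.g-1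

Compound 3 stands highest of the three, and both other compounds lie beyond the scatter from it: a 3.0-fold higher number from compound 1 to compound 3 (0.47 log units; beyond the scatter) and a 4.4-fold higher number from compound 2 to compound 3 (0.64 log units; beyond the scatter). The two lower compounds, by contrast, sit close together, since a 1.5-fold lower number from compound 1 to compound 2 (0.17 log units; within the scatter).

The next compound, compound 4, `CS(=O)(=O)c1ccc(-c2cc(C(O)(C(F)(F)F)C(F)(F)F)cnc2N2CCN(S(=O)(=O)c3ccc(N)nc3)CC2)cc1`, keeps the shared core of compound 3 and changes one group:

4-(methylsulfonyl)phenyl in place of 1-ethyl-1H-pyrazol-4-yl on an aromatic carbon

Among the measured compounds shown here, two measured steps bear on this change, as both alter the group at the same aromatic carbon: the one from compound 1 to compound 3 and the one from compound 2 to compound 3, each modest in size and each ending at the high number of compound 3. For the measured compounds named here, no measured compound carries the entering 4-(methylsulfonyl)phenyl group, so the direction rests only on the fact that every other group seen at this position gave a lower number than the 1-ethyl-1H-pyrazol-4-yl of compound 3. A modest fall is therefore expected, estimated as a 3.0-fold lower number from compound 3 to compound 4 (0.47 log units; beyond the scatter). Compound 4 is accordingly estimated at 65 mL.min-1.g-1, with a range from 25 mL.min-1.g-1 to 160 mL.min-1.g-1.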

Compound 4, intrinsic clearance in microsomes: 103 mL.min-1.g-1
Estimate against measurement, compound 4: 1.6-fold (0.20 log units) below; measured number inside the range.
By their numbers in this assay, from the lowest: compounds 2, 1, 4 and 3 (each within the scatter of the next, the first and the last beyond it).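

In this assay this aromatic carbon now carries a six-membered aromatic ring of carbon only, with 10 heavy atoms in place of the 7 in 1-ethyl-1H-pyrazol-4-yl, and the result is a 1.9-fold lower number from compound 3 to compound 4 (0.27 log units; within the scatter) so the two groups cannot be told apart here. The 3-hydroxyprop-1-yn-1-yl group cannot be told apart from the new group either, with a 1.6-fold higher number from compound 1 to compound 4 (0.20 log units; within the scatter) and only a 2.3-fold higher number from compound 2 to compound 4 (0.37 log units; beyond the scatter) clearing the scatter among the three new steps. Compound 4 thus sits within the scatter of both compound 1 and compound 3, although those two lie beyond it from each other, so the groups at this position do not fall into two clean sets, and compound 2 stays separate from compound 3 and compound 4 but not from compound 1.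

Nothing available here explains why these groups give the numbers they do. Also open, from the compounds shown here alone, is how a plain phenyl group, a phenyl ring carrying a carboxylic acid in place of the methylsulfonyl, or a pyrazole with a propyl chain in place of the ethyl would behave at this aromatic carbon in this assay.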